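The compounds below may be only part of what the source reports. "The series", "measured", "known", "first", "only" and "open" are said of these compounds alone.

Compound 1 `COc1ccc(Cc2nnc(NC(=O)/C(C#N)=C/c3ccccc3OS(=O)(=O)c3ccc(Cl)cc3)s2)cc1`: 79%
Compound 2 `N#C/C(=C\c1ccccc1OS(=O)(=O)c1ccc(Cl)cc1)C(=O)Nc1nnc(Cc2ccccc2)s1`: 73%
Compound 3 `N#C/C(=C\c1ccccc1OS(=O)(=O)c1ccc(F)cc1)C(=O)Nc1nnc(Cc2ccccc2)s1`: 69%

These three compounds were tested in a functional assay on RS4-11 cells (Homo sapiens) for inhibition, read by CCK-8 assay, with a stated time of 48 h, tested at 20 uM; a lower number here means less inhibition of growth, a higher number more inhibition of growth at the concentration tested. Compound 2 gives 73%, the middle number of the three, but the scatter does not separate it from either of the others. The two measured steps are a number 6 percentage points lower from compound 1 to compound 2 (within the scatter) and a number 4 percentage points lower from compound 2 to compound 3 (within the scatter).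

Compound 4 `N#C/C(=C\c1ccccc1OS(=O)(=O)c1ccc(Cl)cc1)C(=O)Nc1nnc(-c2cccc(F)c2)s1` departs from compound 2 in a different place: 3-fluorophenyl in place of benzyl on an aromatic carbon. In words, 3-fluorophenyl stands in place of benzyl on an aromatic carbon of the five-membered aromatic ring. Neither measured step replaces the benzyl group, so the data offer no direct measure of this change. Among the compounds with values here, the small size of both steps shows only that the changes tried so far left this assay within the scatter, and this gives weak support for expecting little movement here. The expected change is a number 5 percentage points lower from compound 2 to compound 4 (within the scatter), with a wide margin for the untested replacement. Compound 4 is expected to give 68%, within an estimated range of 48% to 85%.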

Compound 4, percent growth inhibition at one concentration: 71%
For compound 4 the middle estimate is 3 percentage points below the measured one, within the range that was stated.
By their numbers in this assay, from the lowest: compounds 3, 4, 2 and 1 (each within the scatter of the next).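

In this assay, within the data shown here, the first replacement of the whole group on this aromatic carbon, 3-fluorophenyl in place of benzyl, gives a number 2 percentage points lower from compound 2 to compound 4 (within the scatter) and so, like the earlier steps, which exchanged only a methoxy or a halogen, it stays within the scatter. An aryl group standing directly on the ring carbon, without the carbon link that benzyl carries, is thus not separated from benzyl in this read-out, and the replacement of 4-methoxybenzyl gives a number 8 percentage points lower from compound 1 to compound 4 (within the scatter) as well. No independent measurement bears on this result.

The compounds shown leave open what happens with a group of another kind at this carbon, such as an amine, a carboxylic acid or a longer alkyl chain. They also leave open whether compounds that cannot be told apart at a single concentration would separate in a full dose-response comparison.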